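The compounds below may be only part of what the source reports. "The series", "measured", "known", "first", "only" and "open" are said of these compounds alone.

Compounds measured so far:
compound 1, `Cc1ccccc1Oc1ccc(N2C[C@@H](C(F)(F)F)C[C@H]2CC(=O)O)cc1` — 73 nM
compound 2, `Cc1cc(OCc2ccccc2)ccc1Oc1ccc(N2C[C@@H](C(F)(F)F)C[C@H]2CC(=O)O)cc1` — 120 nM

In a functional assay on cells for agonist activity at Free fatty acid receptor 1 (Homo sapiens), read by FLIPR and calcium flux, with a stated time of 100 s (on this read-out lower numbers stand for an effect already at smaller amounts and higher numbers for an effect only at larger amounts of compound), compound 1 gives 73 nM and compound 2 gives 120 nM. Among the compounds with values here, the one step between them, a 1.6-fold higher number from compound 1 to compound 2 (0.22 log units; within the scatter), introduced benzyloxy in place of hydrogen on an aromatic carbon and stayed within the scatter, so the two numbers cannot be ordered; compound 2 simply holds the higher of the two numbers, with compound 1 close beside it.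

Compound 3, `COc1ccc(Oc2ccc(N3C[C@@H](C(F)(F)F)C[C@H]3CC(=O)O)cc2)c(C)c1`, has not yet been measured in this assay. It differs from compound 2 by hydrogen in place of phenyl on a saturated chain carbon bound to an oxygen on an aromatic ring: the benzyloxy of compound 2 is cut back to methoxy. Within the data shown here, the only step that bears on this change is a 1.6-fold higher number from compound 1 to compound 2 (0.22 log units; within the scatter), which shows that attaching the whole benzyloxy group to the aromatic carbon did not move the number beyond the scatter. Trimming that group back to methoxy is therefore expected to leave the number roughly where compounds 1 and 2 sit, with the step from compound 2 to compound 3 estimated as a 1.3-fold lower number from compound 2 to compound 3 (0.12 log units; within the scatter). Compound 3 is expected to give about 90 nM, in a range from 40 nM to 200 nM.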

Compound 3, half-maximal effective concentration: 55 nM
The estimate for compound 3 lay 1.6-fold (0.21 log units) above the measured number; the range from low to high includes it.
By their numbers in this assay, from the lowest: compounds 3, 1 and 2 (each within the scatter of the next, the first and the last beyond it).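

In this assay, within the data shown here, cutting benzyloxy back to methoxy on this aromatic ring gives a 2.2-fold lower number from compound 2 to compound 3 (0.34 log units; beyond the scatter), the first step to pass beyond the scatter, though only modestly. Set against hydrogen on the same aromatic carbon, methoxy gives a 1.3-fold lower number from compound 1 to compound 3 (0.12 log units; within the scatter), and benzyloxy gives a 1.6-fold higher number from compound 1 to compound 2 (0.22 log units; within the scatter), so neither group can be told apart from hydrogen and only the two groups set against each other separate at all. The data offer no explanation for this difference between benzyloxy and methoxy.

The compounds shown leave open whether a hydroxy group, an ethoxy group or an amine on that aromatic carbon would read with methoxy, with benzyloxy or with neither, and whether a chain such as phenethyloxy would carry the number further from that of compound 3. Among these compounds, they also leave open whether a fluorine or a methoxy group on the phenyl of the benzyloxy would change the reading, and whether the same step would hold with a core other than the one that all three compounds share.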